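Hydroxypentyl for Cyclopropyl on a Quinoline-Free Scaffold

This account rests on a few compounds, and the source may have more. Where it says the series, first, only, none or still open, it means among the compounds named here.

Compound 1 `COc1nc2ccc(Br)cc2cc1C(c1ccccc1)n1cc(C2CC2)nn1` gives -5.84% in an ADME assay on HeLa cells (Homo sapiens) for cytotoxicity, read by sulforhodamine B assay, with a stated time of 48 h, tested at 10 uM (on this read-out lower numbers stand for less inhibition and higher numbers for more inhibition at the one concentration tested (going by the name of the read-out)), the lowest of the two numbers recorded; its nearest neighbour is compound 2 `CCCCCCCc1cn(C(c2ccccc2)c2cc3cc(Br)ccc3nc2OC)nn1`, which in this assay gives 9.7%. Among the measured compounds shown here, the one measured step, a number 15.5 percentage points higher from compound 1 to compound 2 (beyond the scatter), is a modest increase that lies beyond the scatter and follows from a heptyl in place of cyclopropyl on an aromatic carbon.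

Compound 3 `COc1nc2ccc(Br)cc2cc1C(c1ccccc1)n1cc(CCCCCO)nn1` has not yet been measured. It differs from compound 1 by 5-hydroxypentyl in place of cyclopropyl on an aromatic carbon. For the measured compounds named here, the only step that bears on this change is the one from compound 1 to compound 2, where a chain likewise replaced the cyclopropyl; it was worth a number 15.5 percentage points higher from compound 1 to compound 2 (beyond the scatter). Going by the values given here, the 5-hydroxypentyl chain is shorter than heptyl and carries a hydroxyl, so the data give no direct precedent for it. The account therefore expects, if anything, a small rise in this assay that may not exceed the scatter.

The estimated step is a number 7.8 percentage points higher from compound 1 to compound 3 (within the scatter). Compound 3 is expected to give about 2% in this assay, within a range from -10% to 14%.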

Compound 3, a percentage reported as inhibition, at one concentration (the size of the read-out at that concentration, not a potency): 1.08%
Estimate against measurement, compound 3: 0.9 percentage points above; the measured number falls inside the stated range.
By their numbers in this assay, from the lowest: compounds 1, 3 and 2 (each within the scatter of the next, the first and the last beyond it).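

On the aromatic carbon of the five-membered aromatic ring with 3 nitrogen, 5-hydroxypentyl in place of cyclopropyl gives a number 6.9 percentage points higher from compound 1 to compound 3 (within the scatter) in this assay and so cannot be told apart from the cyclopropyl compound. Set against heptyl, the same chain with hydroxy in place of ethyl at its far end gives a number 8.6 percentage points lower from compound 2 to compound 3 (within the scatter) and cannot be told apart from that compound either, so this position now holds an open chain ending in hydroxy with no step beyond the scatter on either side, whereas the only such step remains a number 15.5 percentage points higher from compound 1 to compound 2 (beyond the scatter) between the two ends of the series. No measurement shown here accounts for these numbers.

An amine or a carboxylic acid at the end of the chain in place of the hydroxy, or a longer chain at this carbon, could show whether the read-out moves further from that of compound 1 in this assay than heptyl does. The compounds shown also leave open whether the small gaps among compounds 1, 3 and 2 would hold at any concentration other than the one tested.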